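The source may report more compounds than this note shows. Statements on the series, on what has been measured and on what is new or still open speak of the compounds shown alone.

In a functional assay on BGC-823 cells (Homo sapiens) for antiproliferative activity, read by MTT assay, with a stated time of 48 h (a lower number here means a stronger inhibitor, a higher number a weaker inhibitor), three compounds with a shared core have been measured. Compound 1 (`Clc1ccccc1CSc1nnc(-c2cnccn2)n1-c1ccccc1`) gives 34700 nM, compound 2 (`Fc1ccc(CSc2nnc(-c3cnccn3)n2-c2ccccc2)cc1`) gives 27200 nM, and compound 3 (`Clc1ccc(CSc2nnc(-c3cnccn3)n2-c2ccccc2)cc1`) gives 27700 nM. Compound 3 therefore stands close to both others, with a 1.3-fold lower number from compound 1 to compound 3 (0.10 log units; within the scatter) and a 1.0-fold higher number from compound 2 to compound 3 (0.01 log units; within the scatter). Compound 4 (`Fc1cccc(F)c1CSc1nnc(-c2cnccn2)n1-c1ccccc1`) has not yet been measured. It differs from compound 3 by 2,6-difluorophenyl in place of 4-chlorophenyl on a saturated chain carbon bound to a sulfur. The measured steps at this place bear most directly on the change, and the remaining one, a 1.3-fold lower number from compound 1 to compound 2 (0.11 log units; within the scatter), is equally small. None of the three compounds carries 2,6-difluorophenyl, so the measurements give only indirect guidance. Since every measured change of this group stayed within the scatter, no larger step is expected in this assay, and no direction can be favoured. The expected change is a 1.1-fold higher number from compound 3 to compound 4 (0.03 log units; within the scatter), which lies within the scatter. For compound 4 the estimated value is 30000 nM, with an expected range from 15000 nM to 60000 nM.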

Compound 4, half-maximal inhibitory concentration: > 50000 nM
Compound 4 ended at the assay's limit (the forecaster's own chance of this, stated with the estimate: 5%); middle value at least 1.6-fold (0.22 log units) away from the limit.
By their numbers in this assay, from the lowest: compounds 2, 3 and 1 (each within the scatter of the next). At a limit, above all of these: compound 4.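

In this assay compound 4 gives > 50000 nM, which is a limit of the assay and not a number. The steps to it are therefore floors only: an at least 1.8-fold higher number from compound 3 to compound 4 (0.25 log units; that floor lies within the scatter), an at least 1.8-fold higher number from compound 2 to compound 4 (0.26 log units; that floor lies within the scatter) and an at least 1.4-fold higher number from compound 1 to compound 4 (0.15 log units; that floor lies within the scatter). With 2,6-difluorophenyl, this place on a saturated chain carbon bound to a sulfur yields for the first time a result that cannot be set within the scatter of the other three compounds, yet these floors do not set it beyond the scatter either, so a real loss is possible but not shown.

On these data alone, how far compound 4 lies past the limit stays open. Also open, as far as these compounds go, is what a methoxy group or a carboxylic acid on this phenyl ring, or a longer chain to it, would give at this place.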